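From Sulfanyl to Sulfonyl on a Shared Core

The compounds below may be only part of what the source reports. "The series", "measured", "known", "first", "only" and "open" are said of these compounds alone.

In a functional assay on DU-145 cells (Homo sapiens) for inhibition, read by trypan blue exclusion, with a stated time of 96 h (on this read-out lower numbers stand for stronger inhibition of growth and higher numbers for weaker inhibition of growth), compound 1 `O=C(/C(=C\c1ccccc1OCc1ccccc1)SCc1ccc(F)cc1)c1ccc(Cl)cc1` gives 1000 nM and stands level with compound 2 `O=C(O)c1ccc(C(=O)/C(=C\c2ccc(Cl)c([N+](=O)[O-])c2)SCc2ccc(Cl)cc2)cc1` at 1000 nM on the same read-out. Compound 3 `O=C(/C(=C\c1ccccc1OCc1ccccc1)S(=O)(=O)c1ccc(F)cc1)c1ccc(Cl)cc1` carries (4-fluorophenyl)sulfonyl in place of (4-fluorobenzyl)sulfanyl on a double-bonded chain carbon bound to a carbonyl carbon and a double-bonded chain carbon. Among the measured compounds shown here, no measured pair shows this exchange, so no shift beyond the scatter is expected in this assay and the estimated move is no change at the digits printed from compound 1 to compound 3 (within the scatter) at most in either direction. For compound 3 the estimate is 1000 nM as a middle value, with 250 nM to 4000 nM as the expected range.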

Compound 3, concentration for 50% growth inhibition: 1000 nM
Compound 3: the middle estimate sits on the measured number at the digits printed, within the range that was stated.
By their numbers in this assay, from the lowest: compounds 1, 2 and 3 (each within the scatter of the next).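

this assay records no change at the digits printed from compound 1 to compound 3 (within the scatter) when (4-fluorophenyl)sulfonyl replaces (4-fluorobenzyl)sulfanyl on a double-bonded chain carbon bound to a carbonyl carbon and a double-bonded chain carbon. Among the compounds shown here, this is the first step read at this place, and on the core of compound 1 it tolerates the exchange of a sulfanyl link for a sulfonyl group without a shift beyond the scatter. No evidence is at hand that bears on this result. From the compounds shown here alone, whether an amine or a longer alkyl chain at this place would move the number remains open, as does whether the same exchange would read alike on the core of compound 2.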